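The source may report more compounds than this note shows. Statements on the series, on what has been measured and on what is new or still open speak of the compounds shown alone.

Compound 2 `COc1ccc(F)cc1CNCCCNc1ccnc2cc(C3CCCCC3)ccc12` is the starting point of this step. In a physicochemical assay for solubility, with a stated time of 18 h, at pH 7.4 (a lower number here means a less soluble compound, a higher number a more soluble compound), compound 2 gives 4200 nM, level with compound 1 `COc1cccc(CNCCCNc2ccnc3cc(C4CCCCC4)ccc23)c1O`, which in this assay gives 4200 nM; these two stand together as the lowest of the three numbers, and the step between them is no change at the digits printed from compound 1 to compound 2 (within the scatter). Compound 3 `COc1cccc(CNCCCNc2ccnc3cc(-c4ccc(F)cc4)ccc23)c1O` gives 32000 nM in this assay, and the step of a 7.6-fold higher number from compound 1 to compound 3 (0.88 log units; beyond the scatter) is the only one beyond the scatter.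

Compound 4 `COc1ccc(F)cc1CNCCCNc1ccnc2cc(CCc3ccccc3)ccc12` is not yet measured. The change from compound 2 is phenethyl in place of cyclohexyl on an aromatic carbon. The step of a 7.6-fold higher number from compound 1 to compound 3 (0.88 log units; beyond the scatter) bears on it most directly: there too the cyclohexyl on an aromatic carbon gave way to a group holding an aromatic ring. The step of no change at the digits printed from compound 1 to compound 2 (within the scatter) shows that the part of the structure shared by compound 2 and compound 4 made no difference at the digits shown, so it does not complicate the reading. Within the data shown here, no measured pair shows a phenethyl on an aromatic carbon, so the size is uncertain. For compound 4 in this assay an expected step of a 2.1-fold higher number from compound 2 to compound 4 (0.33 log units; beyond the scatter) is taken, upward but smaller than that seen for the 4-fluorophenyl. Compound 4 is estimated at 9000 nM, in the range 3000 nM to 27000 nM.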

Compound 4, solubility: 4200 nM
The estimate for compound 4 lay 2.1-fold (0.33 log units) above the measured number; measured number inside the range.
By their numbers in this assay, from the lowest: compounds 1, 2 and 4 (each within the scatter of the next); then compound 3.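

In this assay, replacing cyclohexyl with phenethyl on this aromatic carbon gives no change at the digits printed from compound 2 to compound 4 (within the scatter), so the position takes the entering group of 8 heavy atoms without a step beyond the scatter. An aromatic ring in the entering group is therefore not enough on its own to give a higher number here: 4-fluorophenyl in place of cyclohexyl gave a 7.6-fold higher number from compound 1 to compound 3 (0.88 log units; beyond the scatter), whereas phenethyl, which also holds one six-membered aromatic ring, does not repeat that step on the compound 2 background. No measurement at hand bears on what lies behind this difference between the two steps.

Still open, on these data alone, is whether 4-fluorophenyl at this position would give a comparable step with 5-fluoro-2-methoxyphenyl on the chain, as the step to compound 3 was read with 2-hydroxy-3-methoxyphenyl in that place. Also open, as far as these compounds go, is how an unsubstituted phenyl, a benzyl, a longer 3-phenylpropyl chain or a phenethyl carrying a carboxylic acid would read on the same aromatic carbon, and whether any of these would separate the effect of the linking chain from that of the ring.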